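A Halogenated Ring Returns to the Carbonyl Carbon

The source may hold more compounds than are shown below. What is called first, only, known or untested is meant among the compounds shown, and "the series" means these compounds.

Compound 1 `COc1cc(-c2cc(/C=C/C(=O)c3ccc(Cl)c(Cl)c3)[nH]n2)cc(OC)c1OC` — in a functional assay on SNB-19 cells (Homo sapiens) for inhibition, read by sulforhodamine B assay, with a stated time of 48 h (on this read-out higher numbers stand for lower toxicity in this test and lower numbers for higher toxicity in this test), compound 1 gives > 100000 nM, which is a limit of the assay rather than a number.
Compound 2 `COc1ccc(C(=O)/C=C/c2cc(-c3cc(OC)c(OC)c(OC)c3)n[nH]2)cc1OC` — in this assay compound 2 gives 6360 nM.

Within the data shown here, compound 2 therefore holds the only value reported as a number in this assay. Compound 3 `COc1cc(-c2cc(/C=C/C(=O)c3ccc(F)c(F)c3)[nH]n2)cc(OC)c1OC` differs from it by 3,4-difluorophenyl in place of 3,4-dimethoxyphenyl on a carbonyl carbon. Among the measured compounds shown here, the one measured step, an at least 15-fold lower number from compound 1 to compound 2 (1.19 log units; beyond the scatter), went the opposite way, trading a 3,4-dichlorophenyl for the 3,4-dimethoxyphenyl. Undoing that exchange with a different halogen is expected to push the number back up, a 6.3-fold higher number from compound 2 to compound 3 (0.80 log units; beyond the scatter). Compound 3 is estimated at 40000 nM, between 8000 nM and 100000 nM, with a fair chance that only a limit is returned.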

Compound 3, concentration lethal to 50% of the cells: > 100000 nM
Compound 3: only a limit was reported; the forecaster's own chance of this, stated with the estimate: 40%; at least 2.5-fold (0.39 log units) between middle value and limit.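

The change to 3,4-difluorophenyl on a carbonyl carbon gives an at least 15-fold higher number from compound 2 to compound 3 (1.19 log units; beyond the scatter), so the 3,4-dimethoxyphenyl of compound 2 is now set against two halogenated rings, and each of those returns only a limit. The step from compound 1 to compound 3 cannot be read, because neither compound has a number: the limit of > 100000 nM in this assay, at which 2 of the 3 values shown sit.

Still open, as far as these compounds go, is whether the methoxy groups themselves matter here, or whether a single methoxy group, a 3,4-diethoxyphenyl or a ring carrying an amine on this carbonyl carbon would also return a number.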